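The source may hold more compounds than are shown below. What is called first, only, known or untested is meant among the compounds shown, and "the series" means these compounds.

Of the compounds shown here, three built on one shared core have been tested in a functional assay on HEK293 cells for agonist activity at Free fatty acid receptor 1 (Rattus norvegicus), read by FLIPR and calcium flux; a higher number here means that more compound is needed for the effect, a lower number that less compound is needed. Compound 1 `COc1ccc(F)c([C@H]2CC[C@H](COc3cccc([C@@H](CC(=O)O)C4CC4)c3)CC2)c1` gives 4.1 nM, the lowest number of the three. Compound 2 `COc1ccc(F)c([C@H]2CC[C@H](COc3cccc([C@H](C4CC4)[C@@H](C)C(=O)O)c3)CC2)c1` gives 4.9 nM, and compound 3 `COc1ccc(F)c([C@H]2CC[C@H](COc3cccc([C@H](C4CC4)[C@@H](F)C(=O)O)c3)CC2)c1` gives 28 nM. The step of a 1.2-fold higher number from compound 1 to compound 2 (0.08 log units; within the scatter) shows that a methyl in place of hydrogen on a saturated chain carbon bound to a carbonyl carbon and a saturated chain carbon leaves the number essentially unchanged, whereas a 6.8-fold higher number from compound 1 to compound 3 (0.83 log units; beyond the scatter) and a 5.7-fold higher number from compound 2 to compound 3 (0.76 log units; beyond the scatter) show that a fluoro at that same kind of carbon raises the number by a modest but real amount.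

Compound 4 `COc1ccc(F)c([C@H]2CC[C@H](COc3cccc([C@H](C4CC4)C(F)(F)C(=O)O)c3)CC2)c1` has not yet been measured. It differs from compound 1 by carboxy(difluoro)methyl in place of carboxymethyl on a saturated chain carbon bound to an aromatic carbon and a saturated ring carbon. Going by the values given here, compound 3 carries a single fluoro in that part of the molecule, and compound 4 carries two, so the only precedent that bears on it is the step of a 6.8-fold higher number from compound 1 to compound 3 (0.83 log units; beyond the scatter), which lay beyond the scatter. The methyl of compound 2 made no difference, so it adds little guidance. A rise in the number of roughly the size seen for compound 3, possibly somewhat larger, is therefore expected. Compound 4 is estimated at 45 nM, within a range from 12 nM to 160 nM. That corresponds to an expected step of an 11-fold higher number from compound 1 to compound 4 (1.04 log units; beyond the scatter).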

Compound 4, half-maximal effective concentration: 34 nM
The estimate for compound 4 lay 1.3-fold (0.12 log units) above the measured number; the range from low to high includes it.
By their numbers in this assay, from the lowest: compounds 1 and 2 (each within the scatter of the next); then compounds 3 and 4 (each within the scatter of the next).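

In this assay, carboxy(difluoro)methyl in place of carboxymethyl gives an 8.3-fold higher number from compound 1 to compound 4 (0.92 log units; beyond the scatter), so the rise first seen with a single fluoro also holds with two. The second fluoro adds nothing that can be read: a 1.2-fold higher number from compound 3 to compound 4 (0.08 log units; within the scatter) leaves compounds 3 and 4 indistinguishable, so across these compounds the rise does not build with the number of fluorines. Compound 2, with its methyl, stays apart from the difluoro compound, as a 6.9-fold higher number from compound 2 to compound 4 (0.84 log units; beyond the scatter) shows, so the outcome depends on which group is introduced and not simply on a hydrogen being replaced.

Nothing available here explains why the fluorinated compounds and the methyl compound differ. From the compounds shown here alone, it remains open whether a hydroxyl, a chloro or an ethyl on a saturated chain carbon bound to a carbonyl carbon and a saturated chain carbon would fall with the methyl of compound 2 or with the fluorines of compounds 3 and 4, and whether a primary amide could stand in place of the carboxylic acid.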